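This account rests on a few compounds, and the source may have more. Where it says the series, first, only, none or still open, it means among the compounds named here.

Compound 1 `O=C1NC(=O)/C(=C\c2ccc(OCC(=O)N3N=C(c4ccccc4)CC3c3ccc(F)cc3)cc2)S1` — 1700 nM
Compound 2 `Cc1ccc(C2CC(c3ccccc3)=NN2C(=O)COc2ccc(/C=C3/SC(=O)NC3=O)cc2)cc1` — 1200 nM

In an assay on cells for inhibition of histone deacetylase 4 (Homo sapiens), read by fluorescence, with a stated time of 30 min (a lower number here means a stronger inhibitor, a higher number a weaker inhibitor), compound 2 gives 1200 nM, and compound 1 gives 1700 nM; the two numbers sit within the scatter of each other, so neither can be called the stronger inhibitor. Going by the values given here, only one measured step bears on the change considered below: a 1.4-fold lower number from compound 1 to compound 2 (0.15 log units; within the scatter), a swap of one small group on the same aromatic carbon that left the number essentially unchanged. Compound 3 `O=C1NC(=O)/C(=C\c2ccc(OCC(=O)N3N=C(c4ccccc4)CC3c3ccc(Br)cc3)cc2)S1` continues this series with bromo in place of methyl on an aromatic carbon. Among the compounds with values here, since the one comparable exchange at this position stayed within the scatter, no step beyond the scatter is expected here either, in either direction. Compound 3 is therefore estimated to give 1200 nM in this assay, within a range of 500 nM to 2800 nM. The expected step is no change at the digits printed from compound 2 to compound 3 (within the scatter), which is to say no real movement.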

Compound 3, half-maximal inhibitory concentration: 1200 nM
Compound 3: the middle estimate sits on the measured number at the digits printed, and the stated range covers the measured number.
By their numbers in this assay, from the lowest: compounds 2, 3 and 1 (each within the scatter of the next).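

In this assay the bromo compound adds two readings at this place, no change at the digits printed from compound 2 to compound 3 (within the scatter) and a 1.4-fold lower number from compound 1 to compound 3 (0.15 log units; within the scatter), and neither lies beyond the scatter. Where the earlier compounds offered a single exchange, fluoro, methyl and bromo can now be compared in pairs on the aromatic carbon para to a large group, and none of the three pairs separates. No measurement shown gives a reason for this flat result.

As far as these compounds go, whether an amine, a carboxylic acid or a longer chain on the same carbon would produce a step beyond the scatter remains open. From the compounds shown here alone, the rest of the shared core is identical in all three compounds, so the effect of an exchange elsewhere on it also remains open.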